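Side-group exchange from compound 1 to compound 4

The compounds below may be only part of what the source reports. "The series", "measured", "known", "first", "only" and "open" are said of these compounds alone.

In a functional assay on A-375 cells (Homo sapiens) for cytotoxicity, read by MTT assay, with a stated time of 72 h (on this read-out lower numbers stand for stronger inhibition and higher numbers for weaker inhibition), compound 1 `CC1(C)OCC(Cn2cc(Cn3c4c(c5ccccc53)C(=O)c3c[n+]([O-])c5ccccc5c3C4=O)nn2)O1` gives 330 nM while compound 2 `CN1CCN(CCCn2c3c(c4ccccc42)C(=O)c2c[n+]([O-])c4ccccc4c2C3=O)CC1` gives 470 nM and compound 3 `CN1CCN(CCCCCCn2c3c(c4ccccc42)C(=O)c2c[n+]([O-])c4ccccc4c2C3=O)CC1` gives 630 nM so compound 1 stands level with both, all three values lying within the scatter of one another.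

Compound 4 `O=C1c2c[n+]([O-])c3ccccc3c2C(=O)c2c1c1ccccc1n2Cc1cn([C@@H]2O[C@H](CO)[C@@H](O)[C@H](O)[C@H]2O)nn1` keeps the core of compound 1 and differs by 3,4,5-trihydroxy-6-(hydroxymethyl)oxan-2-yl in place of (2,2-dimethyl-1,3-dioxolan-4-yl)methyl on an aromatic nitrogen on an aromatic nitrogen of a five-membered aromatic ring with 3 nitrogen.

Among the measured compounds shown here, the one measured step is a 1.3-fold higher number from compound 2 to compound 3 (0.13 log units; within the scatter) and it bears only loosely on this change, as it concerns a lengthened chain on compound 3 and not the group entering here. For the measured compounds named here, no measured compound carries 3,4,5-trihydroxy-6-(hydroxymethyl)oxan-2-yl, so the data leave both size and direction open. With so large an exchange untested, a cautious lean towards a higher number is expected, and the estimate means a 2.4-fold higher number from compound 1 to compound 4 (0.38 log units; beyond the scatter) as the expected step. For compound 4 the estimated value is 800 nM with an expected range from 300 nM to 2500 nM as its ends.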

Compound 4, half-maximal inhibitory concentration: 230 nM
The estimate for compound 4 lay 3.5-fold (0.54 log units) above the measured number; the measured number lies below the stated range.
By their numbers in this assay, from the lowest: compounds 4, 1, 2 and 3 (each within the scatter of the next, the first and the last beyond it).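

In this assay, 3,4,5-trihydroxy-6-(hydroxymethyl)oxan-2-yl in place of (2,2-dimethyl-1,3-dioxolan-4-yl)methyl on an aromatic nitrogen of a five-membered aromatic ring with 3 nitrogen gives a 1.4-fold lower number from compound 1 to compound 4 (0.16 log units; within the scatter). This position therefore tolerates a change from a five-membered to a six-membered non-aromatic ring, with more heavy atoms, added hydrogen-bond donors and defined stereocentres, without the read-out leaving the scatter. Nothing available explains why the two compounds stay level.

The compounds shown leave open whether a carboxylic acid or a tertiary amine on this same aromatic nitrogen would also stay level with compound 1. They also leave open whether the defined stereocentres of the entering group matter, as only one arrangement of them appears here.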